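The compounds below may be only part of what the source reports. "The series", "measured", "known", "first", "only" and "open" are said of these compounds alone.

Working notes on the series. For the measured compounds named here, in a functional assay on MDA-MB-231 cells (Homo sapiens) for cytotoxicity, read by MTT assay, with a stated time of 72 h (on this read-out lower numbers stand for stronger inhibition and higher numbers for weaker inhibition), compound 1 (`CN(C)Cc1ccc2nc(NC(=O)N/N=C/c3cn(Cc4ccc(C(C)(C)C)cc4)c4ccccc34)sc2c1`) gives 2230 nM and compound 2 (`CN(C)Cc1ccc2nc(NC(=O)N/N=C/c3cn(Cc4ccccc4)c4ccccc34)sc2c1`) gives 1340 nM as the only two numbers so far, so compound 2 stands within the scatter of compound 1 and neither can be ranked. Compound 3 (`CN(C)Cc1ccc2nc(NC(=O)N/N=C/c3cn(Cc4cccc(Cl)c4)c4ccccc34)sc2c1`) carries chloro in place of hydrogen on an aromatic carbon, which turns benzyl into 3-chlorobenzyl. Going by the values given here, the one measured step on this ring, hydrogen in place of tert-butyl, is a 1.7-fold lower number from compound 1 to compound 2 (0.22 log units; within the scatter) and offers the only guide. Chloro itself has not been measured in the series, so in this assay no step beyond the scatter is expected. The expected value for compound 3 is 1200 nM with an estimated range of 500 nM to 2800 nM on this read-out. This estimate means an expected 1.1-fold lower number from compound 2 to compound 3 (0.05 log units; within the scatter) at its middle.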

Compound 3, half-maximal inhibitory concentration: 1140 nM
Compound 3: the middle estimate sits 1.1-fold (0.02 log units) above what was measured; the range from low to high includes it.
By their numbers in this assay, from the lowest: compounds 3, 2 and 1 (each within the scatter of the next).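

In this assay, chloro on the six-membered aromatic ring, meta to a large group, turns benzyl into 3-chlorobenzyl with a 1.2-fold lower number from compound 2 to compound 3 (0.07 log units; within the scatter), so this position takes a single chlorine without a step beyond the scatter. Replacing the 4-(tert-butyl)phenyl of compound 1 with 3-chlorophenyl gives a 2.0-fold lower number from compound 1 to compound 3 (0.29 log units; within the scatter), so compounds 1, 2 and 3 remain unranked even though hydrogen, chloro and tert-butyl differ widely in size. No evidence is available on what lies behind these close numbers.

The compounds shown leave open whether a group of another kind on this ring, such as an amine or a carboxylic acid, would produce a step beyond the scatter. They also leave open whether chloro on another carbon of this ring would read the same.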